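From formyl to dimethylsulfamoyl on an amine nitrogen

This account rests on a few compounds, and the source may have more. Where it says the series, first, only, none or still open, it means among the compounds named here.

Measured in an ADME assay on L02 cells (Homo sapiens) for cytotoxicity, read by MTT assay, with a stated time of 48 h; a higher number here means a weaker inhibitor, a lower number a stronger inhibitor:
Compound 1 `CCN1CCN(C[C@H]2CN(c3ccc(-n4cc(-c5ccccn5)cn4)c(F)c3)C(=O)O2)CC1`: 99 ug/mL
Compound 2 `O=C1O[C@@H](Cn2ccnn2)CN1c1ccc(-n2cc(-c3ccccn3)cn2)c(F)c1`: 49 ug/mL
Compound 3 `O=CNC[C@H]1CN(c2ccc(-n3cc(-c4ccccn4)cn3)c(F)c2)C(=O)O1`: > 400 ug/mL (a limit of the assay)

Compound 3 gives only a limit, > 400 ug/mL, so no exact number exists for it. It still sits highest of the three, as two measured steps show: an at least 4.0-fold higher number from compound 1 to compound 3 (0.60 log units; beyond the scatter) and an at least 8.1-fold higher number from compound 2 to compound 3 (0.91 log units; beyond the scatter). Both of these replace the group on the same saturated chain carbon, and both end at the limit.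

Compound 4 `CN(C)S(=O)(=O)NC[C@H]1CN(c2ccc(-n3cc(-c4ccccn4)cn3)c(F)c2)C(=O)O1` carries dimethylsulfamoyl in place of formyl on an amine nitrogen. For the measured compounds named here, no measured step tests dimethylsulfamoyl itself, so the evidence is indirect. The two groups measured in place of formylamino both gave real numbers, with compound 1 at 99 ug/mL and compound 2 at 49 ug/mL. On that basis, a modest move to a lower number in this assay is expected, though compound 4 could also stay at the limit. The expected change is an at least 2.0-fold lower number from compound 3 to compound 4 (0.30 log units; that floor lies within the scatter). The estimate for compound 4 is 200 ug/mL, with an expected range of 70 ug/mL to 500 ug/mL.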

Compound 4, half-maximal inhibitory concentration: 158 ug/mL
Compound 4: middle estimate off by 1.3-fold (0.10 log units), on the high side, and the stated range covers the measured number.
By their numbers in this assay, from the lowest: compound 2; then compounds 1 and 4 (each within the scatter of the next). At a limit, above all of these: compound 3.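

Compound 3 remains a limit and not a number: the limit of > 400 ug/mL in this assay, at which 1 of the 4 values shown sits.

In this assay, for the compounds shown here, changing only the group on the amine nitrogen is enough to leave that limit, with an at least 2.5-fold lower number from compound 3 to compound 4 (0.40 log units; beyond the scatter), whereas the earlier steps from compound 3 exchanged the whole formylamino group. The (dimethylsulfamoyl)amino group does not match the 1H-1,2,3-triazol-1-yl group, as shown by a 3.2-fold higher number from compound 2 to compound 4 (0.51 log units; beyond the scatter), while a 1.6-fold higher number from compound 1 to compound 4 (0.20 log units; within the scatter) leaves it unresolved from the 4-ethylpiperazin-1-yl group.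

On these data alone, the true size of the step from formyl stays open, since only a limit stands for compound 3. Also open, as far as these compounds go, is whether another group on this amine nitrogen, such as acetyl or methanesulfonyl, would stay at the limit or give a number close to that of compound 4.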